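The source may hold more compounds than are shown below. What is called first, only, known or untested is meant among the compounds shown, and "the series" means these compounds.

Measured in a functional assay on MGC-803 cells (Homo sapiens) for inhibition, read by MTT assay, with a stated time of 72 h; on this read-out higher numbers stand for weaker inhibition and lower numbers for stronger inhibition:

- Compound 1 `C[C@@H]1CCN(c2cc(-c3ccccc3)nc3ncnn23)C[C@@H]1N(C)c1ncnc2[nH]ccc12`: 84900 nM
- Compound 2 `Cc1cc(N2CC[C@@H](C)[C@@H](N(C)c3ncnc4[nH]ccc34)C2)n2nc(SCc3csc4ccc(Cl)cc34)nc2n1`: > 100000 nM (a limit, not a number)
- Compound 3 `CCc1cc(N2CC[C@@H](C)[C@@H](N(C)c3ncnc4[nH]ccc34)C2)n2ncnc2n1`: 80200 nM

Compound 2 stands at the limit of > 100000 nM in this assay, at which 1 of the 3 values shown sits, so it has a limit and no exact number. Compound 4 `Cc1cc(N2CC[C@@H](C)[C@@H](N(C)c3ncnc4[nH]ccc34)C2)n2nc(SCc3cc(Cl)ccc3Cl)nc2n1` differs from compound 2 in a single group, (2,5-dichlorophenyl in place of 5-chloro-1-benzothiophen-3-yl on a saturated chain carbon bound to a sulfur). In short, 2,5-dichlorophenyl takes the place of 5-chloro-1-benzothiophen-3-yl on a saturated chain carbon bound to a sulfur.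

Going by the values given here, the only measured step, a 1.1-fold lower number from compound 1 to compound 3 (0.02 log units; within the scatter), puts ethyl in place of phenyl on an aromatic carbon. Among the compounds with values here, that is a different change in a different place, so it bears on this swap only loosely, and no measured step covers the group being changed here. Going by a 1.1-fold lower number from compound 1 to compound 3 (0.02 log units; within the scatter), which stayed within the scatter, no clear step in either direction is expected in this assay. The estimated step is an at least 1.0-fold lower number from compound 2 to compound 4 (0.02 log units; that floor lies within the scatter). For compound 4 the expected value is 95000 nM, with an estimated range from 45000 nM to 200000 nM.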

Compound 4, half-maximal inhibitory concentration: 9850 nM
Estimate against measurement, compound 4: 9.6-fold (0.98 log units) above, outside the stated range (below it).
By their numbers in this assay, from the lowest: compound 4; then compounds 3 and 1 (each within the scatter of the next). At a limit, above all of these: compound 2.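

In this assay, the group on the saturated chain carbon bound to a sulfur clearly matters: 2,5-dichlorophenyl in place of 5-chloro-1-benzothiophen-3-yl gives an at least 10-fold lower number from compound 2 to compound 4 (1.00 log units; beyond the scatter). Going by these compounds alone, this is the first step beyond the scatter, whereas the earlier swap of phenyl for ethyl on an aromatic carbon, a 1.1-fold lower number from compound 1 to compound 3 (0.02 log units; within the scatter), showed no readable change. Compound 2 holds a limit rather than a number, so the true step could be larger: the limit of > 100000 nM in this assay, at which 1 of the 4 values shown sits.

Which part of the swap counts, the five-membered aromatic ring that leaves or the second chlorine that enters, stays open, as the two groups differ in both. Also open, as far as these compounds go, is what an unsubstituted phenyl, or a phenyl carrying an amine or a carboxylic acid, would do on the same chain carbon.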